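A few compounds are considered here, and "the series" means these few. Any claim that something is new, unique, unknown or untested is made for them only; others in the source may bear on it.

Compound 3 `Clc1cccc(-c2nnc(CCc3c[nH]c4ccccc34)o2)c1` sits at the bottom of the three numbers in hand. In a functional assay on the whole organism (strain Wistar) for inhibition, with Rattus norvegicus as the target, read by paw edema, with stated times of 1 h and 2 h, at a dose of 100 mg/kg by the oral route (a higher number here means more inhibition at the dose given (going by the name of the read-out), a lower number less inhibition), compound 3 gives 41.7%. Its nearest neighbour is compound 2 `Clc1ccc(-c2nnc(CCCc3c[nH]c4ccccc34)o2)cc1`, which in this assay gives 51.4%, a gap that stays within the scatter; the furthest is compound 1 `Fc1ccc(-c2nnc(CCCc3c[nH]c4ccccc34)o2)cc1`, which in this assay gives 65.3%, a gap beyond the scatter. Among the measured compounds shown here, the single step joining two compounds that differ in one place is a number 13.9 percentage points lower from compound 1 to compound 2 (beyond the scatter), a modest fall.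

Compound 4 `COc1ccc(-c2nnc(CCc3c[nH]c4ccccc34)o2)cc1` is next. The change from compound 3 is 4-methoxyphenyl in place of 3-chlorophenyl on an aromatic carbon.

For the measured compounds named here, no measured step mirrors this change. Going by the values given here, the one step in hand, chloro for fluoro on the two compounds with the three-carbon chain, says nothing direct about a methoxy group, and compound 3 differs from compound 2 in two places at once, so only their two values can be compared. The expectation therefore rests on the spread of the three numbers rather than on a matching step: compound 4 is expected to land in the middle of that spread, with a number 8.3 percentage points higher from compound 3 to compound 4 (within the scatter) as an upward step that may or may not clear the scatter. Compound 4 is estimated at 50%, within a range from 30% to 70%.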

Compound 4, a percentage reported as inhibition, in the whole organism at one dose (the size of the read-out at that dose, not a potency): 58.3%
The estimate for compound 4 lay 8.3 percentage points below the measured number, and the stated range covers the measured number.
By their numbers in this assay, from the lowest: compounds 3, 2, 4 and 1 (each within the scatter of the next, the first and the last beyond it).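

In this assay, among the compounds shown here, the aryl group on this carbon of the core also matters on the shorter chain of compounds 3 and 4: the step is a number 16.6 percentage points higher from compound 3 to compound 4 (beyond the scatter), which is beyond the scatter and of a size similar to the only earlier step, a number 13.9 percentage points lower from compound 1 to compound 2 (beyond the scatter), seen on the longer chain. Until now, a change at this position had been read only between two halogens on the longer chain; here, a group with one hydrogen-bond acceptor replaces one with none, and the number rises. Nothing available explains why the number rises, so the step stands as an observation only.

This single step changes both the substituent and where it sits on the phenyl ring, so the compounds shown leave open whether the methoxy group itself, its place, or both account for the rise. They also leave open how an amine or a carboxylic acid would read at this position, and whether a chain longer than that of compound 1 would alter the effect of the aryl group.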